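A few compounds are considered here, and "the series" means these few. Any claim that something is new, unique, unknown or untested is made for them only; others in the source may bear on it.

Working notes on the series. Compound 3 `C/C=C/C(=O)N(Cc1ccc(OC)cc1)c1cc(OC)c(OC)c(OC)c1` gives 500 nM in a functional assay on HCT-116 cells (Homo sapiens) for inhibition, read by MTT assay, with a stated time of 48 h (on this read-out lower numbers stand for stronger inhibition and higher numbers for weaker inhibition), and stands lowest of the three measured numbers. Compound 2 `C/C=C/C(=O)N(Cc1ccc(OC)c(Cl)c1)c1cc(OC)c(OC)c(OC)c1` gives 1420 nM in this assay, and compound 1 `C/C=C/C(=O)N(Cc1ccc(OC)c(C)c1)c1cc(OC)c(OC)c(OC)c1` gives 23500 nM. Among the measured compounds shown here, the steps that bear on the next change are all at the same aromatic carbon: a 47-fold lower number from compound 1 to compound 3 (1.67 log units; beyond the scatter), a 2.8-fold lower number from compound 2 to compound 3 (0.45 log units; beyond the scatter) and a 17-fold lower number from compound 1 to compound 2 (1.22 log units; beyond the scatter). Each group placed there in place of hydrogen gave a higher number than compound 3, chloro by a modest amount and methyl by a large one.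

Compound 4 `C/C=C/C(=O)N(Cc1ccc(OC)c(OC)c1)c1cc(OC)c(OC)c(OC)c1` differs from compound 3 by methoxy in place of hydrogen on an aromatic carbon. Since both measured substituents on that carbon raised the number, a methoxy entering there is expected to do the same, most likely by a step beyond the scatter, though its size between the chloro and methyl cases cannot be fixed from three compounds. Compound 4 is therefore expected to give about 1500 nM, with a range of 400 nM to 6000 nM. This estimate corresponds to an expected step of a 3.0-fold higher number from compound 3 to compound 4 (0.48 log units; beyond the scatter).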

Compound 4, half-maximal inhibitory concentration: 32800 nM
For compound 4 the middle estimate is 22-fold (1.34 log units) below the measured one; measured number outside the range, above it.
By their numbers in this assay, from the lowest: compound 3; then compound 2; then compounds 1 and 4 (each within the scatter of the next).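

In this assay, methoxy on this aromatic carbon, ortho to a methoxy group, does not fall in the modest range seen with chloro: the step from hydrogen is large (a 66-fold higher number from compound 3 to compound 4 (1.82 log units; beyond the scatter)), and the step from chloro is large as well (a 23-fold higher number from compound 2 to compound 4 (1.36 log units; beyond the scatter)). Methoxy and methyl cannot be told apart here (a 1.4-fold higher number from compound 1 to compound 4 (0.14 log units; within the scatter)), so chloro alone stays close to hydrogen, and all three groups at this carbon give a higher number than hydrogen, with no compound shown going against that. Nothing available explains why chloro separates from methoxy and methyl.

Going by these compounds, whether any group on this carbon can match hydrogen or give a lower number stays open, with fluoro, hydroxy or an amine as untested cases. Also open, on these data alone, is whether the same order would hold without the methoxy group ortho to this carbon.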